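The source may hold more compounds than are shown below. What is called first, only, known or untested is meant among the compounds shown, and "the series" means these compounds.

Measured compounds in this series:

compound 1 `CC(=O)c1cc(-c2ccccc2)cc2cc(-c3ccc(F)cc3)[nH]c12` — > 100000 nM
compound 2 `COc1ccc(-c2cc3cc(-c4ccccc4)cc(C(C)=O)c3[nH]2)cc1` — 18900 nM
compound 3 `COc1ccc(-c2cc3cc(-c4ccc(F)cc4)cc(C(C)=O)c3[nH]2)cc1` — 42800 nM

All three were run in a functional assay on HeLa cells (Homo sapiens) for cytotoxicity, read by MTT assay, with a stated time of 2 days; a lower number here means that less compound is tolerated, a higher number that more compound is tolerated. For compound 1 the result is only a limit, > 100000 nM, and not a number. Compound 2 gives 18900 nM and compound 3 gives 42800 nM, which is the highest of the two numbers obtained; the nearest is compound 2.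

The change from compound 1 to compound 2 is methoxy in place of fluoro on an aromatic carbon. It made an at least 5.2-fold lower number from compound 1 to compound 2 (0.72 log units; beyond the scatter). The step from compound 2 to compound 3 is fluoro in place of hydrogen on an aromatic carbon and reads a 2.3-fold higher number from compound 2 to compound 3 (0.35 log units; beyond the scatter). Compound 1 and compound 3 differ in more than one place, and the difference between the two cores is not broken down here.

Compound 4 `COc1ccc(-c2cc(C(C)=O)c3[nH]c(-c4ccc(OC)cc4)cc3c2)cc1` has not yet been measured. It differs from compound 3 by methoxy in place of fluoro on an aromatic carbon, and the place is the same as for the change from compound 1 to compound 2, so it is the same change made a second time. In this assay the earlier step, an at least 5.2-fold lower number from compound 1 to compound 2 (0.72 log units; beyond the scatter), rests on a limit of > 100000 nM in this assay, at which 1 of the 3 values shown sits, at one end, so its true size is not fixed. A step of comparable direction but smaller size is expected from compound 3 to compound 4, namely a 2.9-fold lower number from compound 3 to compound 4 (0.46 log units; beyond the scatter). For compound 4 the estimate in this assay is 15000 nM, expected to fall between 5000 nM and 40000 nM.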

Compound 4, concentration lethal to 50% of the cells: 7130 nM
Compound 4: middle estimate off by 2.1-fold (0.32 log units), on the high side, and the stated range covers the measured number.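

In this assay, the 4-fluorophenyl to 4-methoxyphenyl change reads a 6.0-fold lower number from compound 3 to compound 4 (0.78 log units; beyond the scatter), so the number falls on both cores, and the size of the step on the core of compound 1 is not fixed: the same change on two cores in this assay, an at least 5.2-fold lower number (0.72 log units; beyond the scatter) from compound 1 to compound 2 and a 6.0-fold lower number (0.78 log units; beyond the scatter) from compound 3 to compound 4; the limit leaves it open whether they differ. Compound 1 stands only at a limit, > 100000 nM, so the direction of the change carries from one core to the other, while a match in size is not shown: the limit of > 100000 nM in this assay, at which 1 of the 4 values shown sits. With methoxy in place of hydrogen at the same place reading a 2.7-fold lower number from compound 2 to compound 4 (0.42 log units; beyond the scatter), the three compounds on this core run in the order methoxy, hydrogen, fluoro from the lowest number to the highest, but two cores are too few to show that the change would carry to any further core.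

The compounds shown leave open how other groups at this place would read, for instance an amine, a carboxylic acid or a longer alkoxy chain. The acetyl group is also common to all four compounds, so nothing here tells how the numbers would move if it gave way to an amide or a nitrile.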